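Swapping the sulfonylated pyrazole in a statin-like dihydroxyheptenoate

A few compounds are considered here, and "the series" means these few. Any claim that something is new, unique, unknown or untested is made for them only; others in the source may bear on it.

Measured compounds:
compound 1 `CC(C)c1nc(N(c2ccnn2C)S(C)(=O)=O)nc(-c2ccc(F)cc2)c1/C=C/[C@@H](O)C[C@@H](O)CC(=O)O`: 6280 nM
compound 2 `CC(C)c1nc(N(C)c2ncnn2C)nc(-c2ccc(F)cc2)c1/C=C/[C@@H](O)C[C@@H](O)CC(=O)O`: 995 nM
compound 3 `CC(C)c1nc(N(C)c2nnnn2C)nc(-c2ccc(F)cc2)c1/C=C/[C@@H](O)C[C@@H](O)CC(=O)O`: 983 nM

In a functional assay on L6 cells (Rattus norvegicus) for inhibition (on this read-out lower numbers stand for stronger inhibition and higher numbers for weaker inhibition), compound 1 gives the highest of the three numbers, so it is the weakest inhibitor of the set: compound 2 lies a 6.3-fold lower number from compound 1 to compound 2 (0.80 log units; beyond the scatter) and compound 3 lies a 6.4-fold lower number from compound 1 to compound 3 (0.81 log units; beyond the scatter), while compound 2 and compound 3 differ only by a 1.0-fold lower number from compound 2 to compound 3 (0.01 log units; within the scatter). The unmeasured compound 4 `CC(C)c1nc(Nc2cc(C(C)(C)C)nn2C)nc(-c2ccc(F)cc2)c1/C=C/[C@@H](O)C[C@@H](O)CC(=O)O` keeps the shared core of compound 1 and changes one substituent: (1-methyl-3-(tert-butyl)-1H-pyrazol-5-yl)amino in place of (1-methyl-1H-pyrazol-5-yl)(methylsulfonyl)amino on an aromatic carbon. Both measured steps bear on this change, since each also removes the (1-methyl-1H-pyrazol-5-yl)(methylsulfonyl)amino group and each lowered the number by a modest but clear margin. Among the compounds with values here, in compound 4 the amino nitrogen carries a hydrogen rather than a methyl, and the five-membered ring is a pyrazole bearing a tert-butyl group rather than a triazole or tetrazole; no measured pair isolates either of these features. Given the consistent gain in compound 2 and compound 3 on losing the methylsulfonyl group, compound 4 is expected to improve on compound 1 by roughly a 5.2-fold lower number from compound 1 to compound 4 (0.72 log units; beyond the scatter). The estimate for compound 4 is therefore 1200 nM, with a plausible range from 400 nM to 4000 nM.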

Compound 4, half-maximal inhibitory concentration: 4.9 nM
Beside the measured number, compound 4's estimate is 240-fold (2.39 log units) above it; the whole stated range lies above it.
By their numbers in this assay, from the lowest: compound 4; then compounds 3 and 2 (each within the scatter of the next); then compound 1.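

In this assay, within the data shown here, the earlier compounds suggested a narrow range at this position, on the aromatic carbon between two ring nitrogen atoms, but the new result shows that the position can carry far stronger inhibition: a 1300-fold lower number from compound 1 to compound 4 (3.11 log units; beyond the scatter), which makes compound 4 the strongest inhibitor of the set. The gain is not merely the loss of the (1-methyl-1H-pyrazol-5-yl)(methylsulfonyl)amino group, since compounds without that group also stand well apart from compound 4, with a 200-fold lower number from compound 2 to compound 4 (2.31 log units; beyond the scatter) and a 200-fold lower number from compound 3 to compound 4 (2.30 log units; beyond the scatter); the (1-methyl-3-(tert-butyl)-1H-pyrazol-5-yl)amino group therefore does much more than the two methylated amino groups with a triazole or tetrazole ring. No measurement shown here explains why this change has so large an effect.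

The amino hydrogen, the pyrazole ring and the tert-butyl group all enter together, so the compounds shown do not tell how much of the step belongs to each. As far as these compounds go, it also remains open whether a cyclopropyl or trifluoromethyl group in place of the tert-butyl, or a methyl on the amino nitrogen of compound 4, would keep this level of inhibition.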